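Adding a Methyl Group to the Core of Compound 2

This account rests on a few compounds, and the source may have more. Where it says the series, first, only, none or still open, it means among the compounds named here.

Compound 2 `Cc1cc(Nc2ccc(C(=O)/C=C/c3cccc(Br)n3)cc2)n2nc(SCc3ccc(Cl)cc3)nc2n1` was tested in a functional assay on MGC-803 cells (Homo sapiens) for inhibition, read by sulforhodamine B assay, with a stated time of 72 h, tested at 10 uM (a higher number here means more inhibition at the concentration tested (going by the name of the read-out), a lower number less inhibition), where compound 2 gives 90.2%. For the measured compounds named here, its only measured neighbour is compound 1 `Cc1cc(Nc2ccc(C(=O)/C=C/c3cccc(Br)n3)cc2)n2nc(SCc3ccc(F)cc3)nc2n1`, which in this assay gives 93.3%. Going by the values given here, the one step between them, a number 3.1 percentage points lower from compound 1 to compound 2 (within the scatter), shows that exchanging the halogen on the benzyl sulfide leaves the inhibition essentially unchanged; compound 2 therefore stands as the lower of the two numbers, but within the scatter of compound 1.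

Compound 3 `Cc1nc2nc(SCc3ccc(Cl)cc3)nn2c(Nc2ccc(C(=O)/C=C/c3cccc(Br)n3)cc2)c1C` has not yet been measured in this assay. It differs from compound 2 by methyl in place of hydrogen on an aromatic carbon, that is, a small addition on the shared core rather than a change on the benzyl sulfide. Among the compounds with values here, no measured step touches this part of the molecule, so the halogen step from compound 1 to compound 2 bears only indirectly: it shows that a small peripheral change did not move the read-out beyond the scatter. On that basis the step from compound 2 to compound 3 is expected to be small, a number 2.2 percentage points lower from compound 2 to compound 3 (within the scatter), with no confident direction. Compound 3 is accordingly expected to give about 88%, within a range from 70% to 97%.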

Compound 3, a percentage reported as inhibition, at one concentration (the size of the read-out at that concentration, not a potency): 72.5%
Estimate against measurement, compound 3: 15.5 percentage points above; the range from low to high includes it.
By their numbers in this assay, from the lowest: compound 3; then compounds 2 and 1 (each within the scatter of the next).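

In this assay the aromatic carbon of the shared core, ortho to a large group and ortho to a methyl group, proved more sensitive than the benzyl sulfide: methyl in place of hydrogen there gives a number 17.7 percentage points lower from compound 2 to compound 3 (beyond the scatter) while the halogen exchange gave only a number 3.1 percentage points lower from compound 1 to compound 2 (within the scatter) on the far side of the molecule. A single added carbon at this position is therefore enough to carry the read-out beyond the scatter, so the level numbers seen across the halogen exchange at the benzyl sulfide do not extend to this part of the core. No measurement available here gives a reason for this loss of inhibition.

The compounds shown leave open whether the loss grows with the size of the added group, as an ethyl or a methoxy group at this carbon would test, or whether a different kind of group, such as an amine, would behave otherwise. They also leave open whether the same methyl would have a similar effect alongside the fluoro of compound 1 rather than the chloro of compound 2.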